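A Methoxy Group Gives Way to Hydroxy

The source may report more compounds than this note shows. Statements on the series, on what has been measured and on what is new or still open speak of the compounds shown alone.

Compound 1 `O=C(CCc1nc2ccccc2c(=O)[nH]1)N/N=C/c1ccc(O)c(O)c1`: 105000000 nM
Compound 2 `COc1cc(/C=N/NC(=O)CCc2nc3ccccc3c(=O)[nH]2)cc(OC)c1O`: 275000000 nM

In a physicochemical assay, read by spectrophotometry, with a stated time of 15 min (a lower number here means a stronger inhibitor, a higher number a weaker inhibitor), compound 2 gives 275000000 nM, the higher of the two numbers and so the weaker inhibitor of the pair. Its gap to compound 1 lies beyond the usual scatter.

The next compound to be measured is compound 3 `COc1cc(/C=N/NC(=O)CCc2nc3ccccc3c(=O)[nH]2)cc(O)c1O`. It differs from compound 2 as follows: hydrogen in place of methyl on an oxygen on an aromatic ring. In words, this is hydrogen in place of methyl on an oxygen on an aromatic ring, or methoxy to hydroxy.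

Among the compounds with values here, no measured pair shows this exact change, so the expectation rests on little. Compound 1 carries no methoxy at all and gives 105000000 nM, which points toward a lower number. A small fall in the number is expected for the step of a 2.1-fold lower number from compound 2 to compound 3 (0.33 log units; beyond the scatter). The estimate for compound 3 is 130000000 nM, with an expected range of 65000000 nM to 280000000 nM.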

Compound 3, half-maximal inhibitory concentration: 50000000 nM
Estimate against measurement, compound 3: 2.6-fold (0.41 log units) above, and the stated range ends above it.
By their numbers in this assay, from the lowest: compound 3; then compound 1; then compound 2.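

In this assay, the change from methoxy to hydroxy brings a 5.5-fold lower number from compound 2 to compound 3 (0.74 log units; beyond the scatter), so removing this single methyl from the oxygen shifts the result by more than ordinary measurement scatter. The methoxy group does not raise the number in every setting: with methoxy in place of hydrogen on an aromatic carbon, the series shows a 2.1-fold lower number from compound 1 to compound 3 (0.32 log units; beyond the scatter), so the effect of a methoxy group depends on the exact change made. Nothing shown gives a reason for either step.

From the compounds shown here alone, it remains open whether an amine or a fluorine in that same place would give a number as low as that of compound 3. It is also unknown whether either step would hold if a longer chain linked this aromatic ring to the shared core.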